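The source may report more compounds than this note shows. Statements on the series, on what has been measured and on what is new or still open speak of the compounds shown alone.

Compound 1 `Cc1ccccc1CNC(=O)n1c(N)nc2ccccc21` carries an amino group on its core. For the measured compounds named here, in a physicochemical assay for metabolic stability, read by HPLC, at pH 4.5, tested at 10 uM (on this read-out lower numbers stand for a shorter-lived compound and higher numbers for a longer-lived compound), compound 1 gives 0.45 h, and this is the only plain number among the three measured compounds. Compound 2 `O=C(NCCCCc1ccccc1)n1c(=O)n(C(=O)NCCCCc2ccccc2)c2ccccc21` reaches a limit of the assay, > 2 h. Compound 3 `CCCCCCNC(=O)n1cnc2ccccc21` likewise reaches a limit, > 2 h. Compound 1 therefore stands at the lower end of what has been measured so far, while the two others sit at the limit of > 2 h in this assay, at which 2 of the 3 values shown sit.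

Compound 4 `Cc1ccccc1CNC(=O)n1cnc2ccccc21` has not yet been measured. It differs from compound 1 in one place (hydrogen in place of amino on an aromatic carbon). Going by the values given here, no step between two measured compounds is available, so the size of this change can only be estimated. Compound 3 also carries hydrogen rather than amino on its core and reaches the limit, which suggests that the step upward in this assay will be beyond the usual scatter. The expected step from compound 1 to compound 4 is a 5.6-fold higher number from compound 1 to compound 4 (0.74 log units; beyond the scatter). Compound 4 is expected to give about 2.5 h in this assay, with a likely range from 0.8 h to 8 h, and a fair chance that only a limit is reported.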

Compound 4, half-life: 1.37 h
Compound 4: the middle estimate sits 1.8-fold (0.26 log units) above what was measured, within the range that was stated.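

For the compounds shown here, putting hydrogen in place of amino on the aromatic carbon between two ring nitrogen atoms gives a 3.0-fold higher number from compound 1 to compound 4 (0.48 log units; beyond the scatter) in this assay and is the first change here whose size can be read. So this one position alone moves the half-life by more than the usual scatter, with the rest of the molecule held the same. Compound 4 also gives a plain number, so both ends of this step are real values, unlike the results for compound 2 and compound 3: the limit of > 2 h in this assay, at which 2 of the 4 values shown sit.

This single pair cannot say why the half-life changes, or whether the same change would act alike on a compound with a different side chain. It also leaves open where a methyl group or a chlorine atom on this carbon would fall relative to amino and hydrogen.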